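Sulfanyl chain length on the amidine carbon

The source may hold more compounds than are shown below. What is called first, only, known or untested is meant among the compounds shown, and "the series" means these compounds.

Compound 3 `CC(S)C(=N)NCC(C)(C)C` is the weakest of the three measured compounds: in a functional assay on the whole organism (stomach, strain beagle) for inhibition, with Canis familiaris (Canis lupus familiaris) as the target, with a stated time of 2 h, at a dose of 8 mg/kg (a higher number here means a stronger effect of the compound at the dose given, a lower number a weaker effect), compound 3 gives 0%, whereas compound 1 `CC(C)(C)CNC(=N)CS` gives 95% and compound 2 `N=C(CS)N[C@@H]1C[C@H]2CC[C@H]1C2` gives 94%, both beyond the scatter from compound 3. For the measured compounds named here, the one measured single-point step that reaches compound 3 is a number 95 percentage points lower from compound 1 to compound 3 (beyond the scatter), a complete loss on adding the methyl. Compound 4 `CC(C)(C)CNC(=N)CCCS` differs from compound 3 by 3-sulfanylpropyl in place of 1-sulfanylethyl on a carbon with a double bond to nitrogen. Going by the values given here, this change removes the methyl whose addition caused the loss from compound 1 to compound 3, so a return towards the level of compound 1 is plausible, but it also lengthens the chain carrying the sulfur by two carbons, and no measured pair speaks to chain length. The expected step is therefore upward, a number 50 percentage points higher from compound 3 to compound 4 (beyond the scatter), with wide uncertainty. Compound 4 is estimated at 50% in this assay, within a range of 5% to 95%.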

Compound 4, a percentage reported as inhibition, in the whole organism at one dose (the size of the read-out at that dose, not a potency): 11%
Beside the measured number, compound 4's estimate is 39 percentage points above it, within the range that was stated.
By their numbers in this assay, from the lowest: compound 3; then compound 4; then compounds 2 and 1 (each within the scatter of the next).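

In this assay, replacing the 1-sulfanylethyl group with the unbranched 3-sulfanylpropyl group recovers little, with a number 11 percentage points higher from compound 3 to compound 4 (beyond the scatter). The loss also remains large against the parent chain, with a number 84 percentage points lower from compound 1 to compound 4 (beyond the scatter), so the high level of compound 1 does not return merely on removing the methyl from the carbon bearing sulfur. Among the compounds shown, the high numbers belong to compounds 1 and 2, which share one sulfur-bearing chain, while both altered chains, in compounds 3 and 4, give low numbers; no data here account for either loss.

Open, from the compounds shown here alone, is how the number behaves for a 2-sulfanylethyl group on the carbon with a double bond to nitrogen, a chain length intermediate between those of compounds 1 and 4. Also open, going by these compounds, is whether a hydroxyl or an amine can stand in place of the sulfanyl group on the chain of compound 1.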